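Three Limits and an Untested Analogue at One Receptor

The compounds below may be only part of what the source reports. "The series", "measured", "known", "first", "only" and "open" are said of these compounds alone.

Compound 1 `CCCN(CC1CC1)c1nc(C)nc(Nc2c(C)cccc2C)n1` gives > 10000 nM as a limit.
Compound 2 `CCCN(Cc1ccccc1)c1nc(C)nc(Nc2c(CC)cccc2CC)n1` gives > 10000 nM as a limit.
Compound 3 `CCCN(Cc1ccccc1)c1nc(C)nc(Nc2c(C)cccc2C)n1` gives > 10000 nM as a limit.

All three were tested in an assay on isolated protein for binding affinity to corticotropin-releasing factor receptor 1 (Homo sapiens); a higher number here means a weaker inhibitor, a lower number a stronger inhibitor. None returned a number: for compound 1 the value > 10000 nM is a limit of the assay, for compound 2 the value > 10000 nM is a limit, and for compound 3 the value > 10000 nM is a limit. The change cyclopropyl in place of phenyl on a saturated chain carbon bound to a nitrogen on an aromatic ring therefore gives a step that the two limits leave unreadable from compound 3 to compound 1 whose size is not readable, because of the limit of > 10000 nM in this assay, at which 3 of the 3 values shown sit. The difference between the cores of compound 2 and compound 3 is not broken down here.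

The unmeasured compound 4 `CCCN(CC1CC1)c1nc(C)nc(Nc2c(CC)cccc2CC)n1` is related to compound 2 by the same kind of change, (cyclopropyl in place of phenyl on a saturated chain carbon bound to a nitrogen on an aromatic ring). In this assay the step from compound 2 to compound 4 is expected to be a step that the limit leaves unreadable from compound 2 to compound 4, resting on compound 2 giving only a limit > 10000 nM and on the unreadable step that the two limits leave unreadable from compound 3 to compound 1. Compound 4 is thus estimated at 15000 nM, between 5000 nM and 50000 nM, most likely again only a limit.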

Compound 4, inhibition constant: > 10000 nM
Compound 4: only a limit was reported (the forecaster's own chance of this, stated with the estimate: 85%); the middle value lies beyond the limit too.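

Within the data shown here, compound 4, like compound 2, returned only a limit, so no step between these two compounds can be read, and the change from benzyl to cyclopropylmethyl stays without a size: the limit of > 10000 nM in this assay, at which 4 of the 4 values shown sit. The compounds shown leave open whether any change to them would give a readable value in this assay.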